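Swapping the acyl group on a trimethoxyphenyl amide

The compounds below may be only part of what the source reports. "The series", "measured", "known", "first", "only" and "open" are said of these compounds alone.

Measured so far:
Compound 1, `COc1ccc(CN(C(=O)C=C(C)C)c2cc(OC)c(OC)c(OC)c2)cc1O`, 320 nM
Compound 2, `C/C=C/C(=O)N(Cc1ccc(OC)c(Br)c1)c1cc(OC)c(OC)c(OC)c1`, 6430 nM

In a functional assay on MGC-803 cells (Homo sapiens) for inhibition, read by MTT assay, with a stated time of 48 h (on this read-out lower numbers stand for stronger inhibition and higher numbers for weaker inhibition), compound 1 gives the lower of the two numbers; compound 2 gives a higher number, and that gap lies beyond the scatter of repeated measurements. Compound 3, `COc1ccc(CN(C(=O)CCCCCl)c2cc(OC)c(OC)c(OC)c2)cc1O`, has not been measured. It differs from compound 1 in one place: 4-chlorobutyl in place of 2-methylprop-1-en-1-yl on a carbonyl carbon. Within the data shown here, no measured pair shows this change, so compound 3 is expected to give a somewhat higher number than compound 1, with the step of a 4.7-fold higher number from compound 1 to compound 3 (0.67 log units; beyond the scatter) estimated to lie beyond the scatter. For compound 3 the expected value is 1500 nM, within a range from 300 nM to 8000 nM.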

Compound 3, half-maximal inhibitory concentration: 540 nM
Compound 3: middle estimate off by 2.8-fold (0.44 log units), on the high side, within the range that was stated.
By their numbers in this assay, from the lowest: compounds 1 and 3 (each within the scatter of the next); then compound 2.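

In this assay, the first direct test at this position, putting 4-chlorobutyl in place of 2-methylprop-1-en-1-yl on the carbonyl carbon gives a 1.7-fold higher number from compound 1 to compound 3 (0.23 log units; within the scatter). The change removes the double bond outside aromatic rings and adds a chlorine, yet compound 1 and compound 3 stay within the scatter of each other, so this position tolerates this exchange. Nothing available explains this result. The compounds shown leave open whether the chlorine of the 4-chlorobutyl chain matters, since a plain butyl chain would be needed to tell. They also leave open how an amine, a carboxylic acid or a longer chain on this carbonyl carbon would read.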